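Cyclopentyloxy to cyclohexyloxy on a chloroacetylurea core

The compounds below may be only part of what the source reports. "The series", "measured", "known", "first", "only" and "open" are said of these compounds alone.

Measured compounds:
compound 1, `c1cc(NC2=NCCO2)cc(OC2CCCC2)c1`, 76900 nM
compound 2, `c1cc(NC2=NCCO2)cc(OC2CCCCC2)c1`, 12000 nM
compound 3, `O=C(CCl)NC(=O)Nc1ccc(OC2CCCC2)cc1`, 2900 nM

Of the compounds shown here, three have been tested in a functional assay on M21 cells (Homo sapiens) for inhibition, read by sulforhodamine B assay, with a stated time of 48 h; a higher number here means a weaker inhibitor of growth, a lower number a stronger inhibitor of growth. Compound 1 `c1cc(NC2=NCCO2)cc(OC2CCCC2)c1` gives 76900 nM, and compound 2 `c1cc(NC2=NCCO2)cc(OC2CCCCC2)c1` gives 12000 nM. The two share a core and differ by a single change, (cyclohexyl in place of cyclopentyl on an oxygen on an aromatic ring), which made a 6.4-fold lower number from compound 1 to compound 2 (0.81 log units; beyond the scatter). Compound 3 `O=C(CCl)NC(=O)Nc1ccc(OC2CCCC2)cc1`, built on a different core, gives 2900 nM; the difference between the two cores is not broken down here.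

Compound 4 `O=C(CCl)NC(=O)Nc1ccc(OC2CCCCC2)cc1` has not yet been measured. It is related to compound 3 by cyclohexyl in place of cyclopentyl on an oxygen on an aromatic ring, the same kind of change as that between compound 1 and compound 2, at the same place. This change has appeared only once among the measured compounds, and on another core, so its carry-over to compound 3 is uncertain. For the measured compounds named here, still, the one observed instance is beyond the scatter, and the account expects a step of a 3.6-fold lower number from compound 3 to compound 4 (0.56 log units; beyond the scatter) in this assay, somewhat smaller, because a 6.4-fold lower number from compound 1 to compound 2 (0.81 log units; beyond the scatter) was observed on a core other than that of compound 3. Compound 4 is therefore estimated at 800 nM, within 250 nM to 2600 nM.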

Compound 4, concentration for 50% growth inhibition: 5000 nM
Compound 4: middle estimate off by 6.3-fold (0.80 log units), on the low side, and the stated range ends below it.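

In this assay, cyclohexyl in place of cyclopentyl on the core of compound 3 gives a 1.7-fold higher number from compound 3 to compound 4 (0.24 log units; within the scatter), so the clear drop in the number seen on the core of compound 1 does not carry over to this core. The two instances of the same change disagree by more than the scatter allows: the same change on two cores in this assay, a 6.4-fold lower number (0.81 log units; beyond the scatter) from compound 1 to compound 2 and a 1.7-fold higher number (0.24 log units; within the scatter) from compound 3 to compound 4, 11-fold (1.04 log units) apart, beyond the scatter of two such steps

The step measured on one core is therefore a poor guide to the step on the other in this series, but with a single pair on each core, this does not show what in the cores sets the two results apart or how the change would behave on any further core.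

The compounds shown carry only cyclopentyl and cyclohexyl on the oxygen, so it remains open how a cyclobutyl, a cycloheptyl, a phenyl or an open butyl chain would behave there on either core. Also open, as far as these compounds go, is whether the result on the core of compound 3 would hold if an acetyl group stood in place of the chloroacetyl group.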